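Methoxy on the pendant phenyl in a piperazine-linked series

A few compounds are considered here, and "the series" means these few. Any claim that something is new, unique, unknown or untested is made for them only; others in the source may bear on it.

Compound 1 `Cc1ccc(-c2nnc(N3CCN(C(=O)CN4CCN(c5ccccc5)CC4)CC3)nc2-c2ccc(C)cc2)cc1` is the reference point. In a functional assay on MCF7 cells (Homo sapiens) for cytotoxicity, read by MTT assay, with a stated time of 24 h (a lower number here means a stronger inhibitor, a higher number a weaker inhibitor), compound 1 gives 914000 nM. Compound 2 `COc1cccc(N2CCN(CC(=O)N3CCN(c4nnc(-c5ccc(C)cc5)c(-c5ccc(C)cc5)n4)CC3)CC2)c1` carries methoxy in place of hydrogen on an aromatic carbon on the pendant phenyl; in this assay compound 2 gives 867000 nM, and the step of a 1.1-fold lower number from compound 1 to compound 2 (0.02 log units; within the scatter) lies within the scatter. Compound 3 `COc1ccc(-c2nnc(N3CCN(C(=O)CN4CCN(c5ccccc5)CC4)CC3)nc2-c2ccc(OC)cc2)cc1` has a different core from compound 1; the difference between the two cores is not broken down here. In this assay compound 3 returns only a limit, > 863000 nM, the limit described as the limit of > 863000 nM in this assay, at which 1 of the 3 values shown sits. Compound 4 `COc1ccc(-c2nnc(N3CCN(C(=O)CN4CCN(c5ccccc5OC)CC4)CC3)nc2-c2ccc(OC)cc2)cc1` is not yet measured and differs from compound 3 by methoxy in place of hydrogen on an aromatic carbon. This is the same kind of change as that from compound 1 to compound 2, but the place is not the same: meta to a large group in compound 2, ortho to a large group in compound 4. Because the step of a 1.1-fold lower number from compound 1 to compound 2 (0.02 log units; within the scatter) is within the scatter, the step to compound 4 is estimated as a step that the limit leaves unreadable from compound 3 to compound 4. Compound 4 is expected to give 900000 nM in this assay, within an estimated range from 450000 nM to 1800000 nM. Compound 4 is expected most likely to come back as a limit rather than a number.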

Compound 4, half-maximal inhibitory concentration: > 821000 nM
Compound 4: no number, only a limit; the forecaster's own chance of this, stated with the estimate: 70%; the middle value lies beyond the limit too.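

Compound 3 and compound 4 each return only a limit in this assay; the step between them cannot be read. The compounds shown leave open whether the change from phenyl to 2-methoxyphenyl on the core of compound 3 shifts the result in this assay at all.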